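From a Saturated Ring to a Fluorinated Aromatic One

The compounds below may be only part of what the source reports. "The series", "measured", "known", "first", "only" and "open" are said of these compounds alone.

Measured compounds:
- compound 1, `COc1ccc(F)cc1CNCCCNc1ccnc2cc(C3CCCCC3)ccc12`: 23 10^-6 cm/s
- compound 2, `COc1cccc(CNCCCNc2ccnc3cc(-c4ccc(C(F)(F)F)cc4)ccc23)c1O`: 237 10^-6 cm/s
- compound 3, `CCC(CC)c1ccc2c(NCCCNCc3cccc(OC)c3O)ccnc2c1`: 23 10^-6 cm/s

In an ADME assay for permeability, using PAMPA, with a stated time of 30 min, at pH 7.4 (a higher number here means that the compound crosses the layer faster, a lower number that the compound crosses the layer more slowly), compound 1 gives 23 10^-6 cm/s. On the numbers shown, compound 1 stands level with compound 3 at the digits printed, a gap within the scatter, and the two of them share the lowest value; compound 2 is the furthest away, with a number a decade higher.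

Compound 4, `COc1ccc(F)cc1CNCCCNc1ccnc2cc(-c3ccc(F)cc3)ccc12`, has not yet been measured in this assay. It differs from compound 1 in one place, (4-fluorophenyl in place of cyclohexyl on an aromatic carbon).

Among the compounds with values here, one measured step bears on this change. Between compound 2 and compound 3 the ring on the shared core went the other way, from an aromatic to a saturated group, and the result was a 10-fold lower number from compound 2 to compound 3 (1.01 log units; beyond the scatter). Compound 4 makes the reverse move, from a saturated ring to an aromatic one, so an increase in this assay is expected, of a size a 4.8-fold higher number from compound 1 to compound 4 (0.68 log units; beyond the scatter). Within the data shown here, the size is uncertain because the single supporting step a 10-fold lower number from compound 2 to compound 3 (1.01 log units; beyond the scatter) involves a different aromatic group and a different benzylic part of the molecule.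

Compound 4 is therefore expected to give about 110 10^-6 cm/s, within the range from 35 10^-6 cm/s to 260 10^-6 cm/s.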

Compound 4, apparent permeability: 237 10^-6 cm/s
The estimate for compound 4 lay 2.2-fold (0.33 log units) below the measured number; the measured number falls inside the stated range.
By their numbers in this assay, from the lowest: compounds 1 and 3 (each within the scatter of the next); then compounds 2 and 4 (each within the scatter of the next).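

Within the data shown here, this step is the first direct reading of this change at this position: in this assay, with the rest of compound 1 held fixed, replacing cyclohexyl with 4-fluorophenyl gives a 10-fold higher number from compound 1 to compound 4 (1.01 log units; beyond the scatter) on the shared core. Together with a 10-fold lower number from compound 2 to compound 3 (1.01 log units; beyond the scatter) in a series with a different benzylic part, it gives two measured steps at this carbon, and in both the compound with the aromatic group has the higher number, with neither of the listed steps going against that pattern. Nothing shown gives a measured reason for the rise, so the numbers record its size and direction but not its cause.

The compounds shown leave open how much of the step belongs to the aromatic ring and how much to its fluorine, a question that a plain phenyl group, with hydrogen in place of the fluorine, could help to separate. They also leave open whether the same rise would appear with a pyridine ring at this carbon, or with a phenyl ring carrying an amine or a carboxylic acid.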